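The source may hold more compounds than are shown below. What is called first, only, known or untested is meant among the compounds shown, and "the series" means these compounds.

Measured in an ADME assay on S9 fraction from liver (Rattus norvegicus) for metabolic stability, read by LC-MS, using NADPH, with a stated time of 30 min; on this read-out lower numbers stand for a less stable compound and higher numbers for a more stable compound:

Compound 1 `CCCCCCCCc1ccc(OCC(=O)Cn2ncnn2)cc1`: < 5% (a limit)
Compound 2 `CCCCCCCCc1ccc(OCC(=O)Cn2nnc(SC)n2)cc1`: < 5% (a limit)
Compound 3 `CCCCCCCCc1ccc(OCC(=O)Cn2nnc(-c3ccc(C(=O)OC)cc3)n2)cc1`: 64%

Compound 3 is the only one of the three with a number, and it stands at 64%. Compound 1 and compound 2 both stand at the limit of < 5% in this assay, at which 2 of the 3 values shown sit.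

Compound 4 `CCCCCCCCc1ccc(OCC(=O)Cn2nnc(-c3cccnc3)n2)cc1` has not yet been measured in this assay. It differs from compound 3 in one place: pyridin-3-yl in place of 4-(methoxycarbonyl)phenyl on an aromatic carbon. Pyridin-3-yl takes the place of 4-(methoxycarbonyl)phenyl on an aromatic carbon.

Within the data shown here, the steps that bear on this change are those made at that same place. They show a number at least 59 percentage points higher from compound 1 to compound 3 (beyond the scatter) and a number at least 59 percentage points higher from compound 2 to compound 3 (beyond the scatter). Both are large, and both bring in the group that compound 4 gives up. The third step, a step that the two limits leave unreadable from compound 1 to compound 2, adds little. Among the measured compounds shown here, no measured compound carries pyridin-3-yl, so its effect is not known. Compound 4 keeps a six-membered aromatic ring at this place, as compound 3 does, but not the rest of the group, so part of the gain may be kept and part lost. A clear fall is expected, with wide uncertainty. The estimated step is a number 34 percentage points lower from compound 3 to compound 4 (beyond the scatter). For compound 4 the expected value is 30%, with an estimated range from 6% to 65%.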

Compound 4, percent of the compound remaining: 12%
The estimate for compound 4 lay 18 percentage points above the measured number, within the range that was stated.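

In this assay, pyridin-3-yl in place of 4-(methoxycarbonyl)phenyl gives a number 52 percentage points lower from compound 3 to compound 4 (beyond the scatter), so a six-membered aromatic ring on this aromatic carbon of the five-membered aromatic ring with 4 nitrogen is not enough on its own to hold the number of compound 3. The earlier compounds shown here showed only that the whole 4-(methoxycarbonyl)phenyl group stood far above hydrogen and methylsulfanyl, whereas this change keeps a ring and removes the methoxycarbonyl part, and the number falls sharply with it. Against the other two compounds, the pyridin-3-yl group gives a number at least 7 percentage points higher from compound 2 to compound 4 (that floor lies within the scatter) and a number at least 7 percentage points higher from compound 1 to compound 4 (that floor lies within the scatter), so no gain over methylsulfanyl or hydrogen can be claimed for it.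

Compound 1 and compound 2 remain limits of the assay rather than numbers: the limit of < 5% in this assay, at which 2 of the 4 values shown sit. The compounds shown leave open whether the high number of compound 3 depends on the methoxycarbonyl part or on the carbon-only ring, since the change alters both together, and a plain phenyl, or a carboxylic acid or an amide in place of the methyl ester, would be needed to separate the two.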